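From 3-bromophenyl to 4-methylphenyl on a shared core

The source may report more compounds than this note shows. Statements on the series, on what has been measured and on what is new or still open speak of the compounds shown alone.

- compound 1 `COc1cccc(-c2nc3cccc(-c4cc(OC)c(OC)c(OC)c4)c3o2)c1`: 3500 nM
- compound 2 `COc1cc(-c2cccc3nc(-c4cccc(Br)c4)oc23)cc(OC)c1OC`: 2100 nM

Among the measured compounds shown here, in a functional assay on A549 cells (Homo sapiens) for antiproliferative activity, read by MTT assay, with a stated time of 48 h (on this read-out higher numbers stand for weaker inhibition and lower numbers for stronger inhibition), compound 2 gives 2100 nM, a number within the scatter of the only other measured compound. Compound 3 `COc1cc(-c2cccc3nc(-c4ccc(C)cc4)oc23)cc(OC)c1OC` keeps the shared core and carries 4-methylphenyl in place of 3-bromophenyl on an aromatic carbon. For the measured compounds named here, the only measured step, a 1.7-fold lower number from compound 1 to compound 2 (0.22 log units; within the scatter), is bromo in place of methoxy on an aromatic carbon, and it stays within the scatter, so no clear step is expected in this assay. The expected step is small: a 1.2-fold higher number from compound 2 to compound 3 (0.08 log units; within the scatter). For compound 3 the estimated value is 2500 nM, with an expected range of 900 nM to 7000 nM.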

Compound 3, half-maximal inhibitory concentration: 680 nM
Estimate against measurement, compound 3: 3.7-fold (0.57 log units) above; measured number outside the range, below it.
By their numbers in this assay, from the lowest: compound 3; then compounds 2 and 1 (each within the scatter of the next).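

At this position, next to the ring nitrogen and next to the ring oxygen, changing the aryl group can shift the number in this assay beyond the scatter: 4-methylphenyl gives a 3.1-fold lower number from compound 2 to compound 3 (0.49 log units; beyond the scatter) and also a 5.1-fold lower number from compound 1 to compound 3 (0.71 log units; beyond the scatter) on the same core. Both the substituent and its place on the ring differ in these steps, so neither can be credited alone. Nothing available explains the size of these steps.

Still open, from the compounds shown here alone, is whether 4-bromophenyl or 3-methylphenyl would separate those two changes, and how an amine or a carboxylic acid on this ring would read out.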